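The compounds below may be only part of what the source reports. "The series", "measured", "known", "first", "only" and "open" are said of these compounds alone.

Measured so far:
compound 1 `CCc1nccn1CC#CCN1CCCC1=O`: 2.5 mg/kg
compound 2 `O=C1NCCN1CC#CCn1ccnc1`: > 100 mg/kg (a limit)
compound 3 `CN(C)CC#CCN1CCNC1=O`: > 100 mg/kg (a limit)

In a functional assay on the whole organism for antagonist activity, with Mus musculus as the target (on this read-out higher numbers stand for an effect only at larger amounts of compound and lower numbers for an effect already at smaller amounts), compound 3 gives only a limit, > 100 mg/kg. It thus shares the limit of > 100 mg/kg in this assay, at which 2 of the 3 values shown sit, with one other compound. The change to compound 4 `CN(C)CC#CCN1CCN(C)C1=O` is methyl in place of hydrogen on an amide-type nitrogen in a ring. Among the compounds with values here, the one measured step that reaches compound 3, a step that the two limits leave unreadable from compound 2 to compound 3, concerns a different place, so no measured step bears directly on this change. Compound 4 is therefore expected to stay near the limit in this assay. The expected size is a number no higher from compound 3 to compound 4 (the limit leaves the size open), with nothing beyond the scatter anticipated. For compound 4 the estimate is 100 mg/kg, with an expected range from 40 mg/kg to 250 mg/kg.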

Compound 4, dose for half-maximal effect: > 10 mg/kg
Compound 4: only a limit was reported; the forecaster's own chance of this, stated with the estimate: 70%; the middle value is on the limit's open side.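

In this assay compound 3 gives only a limit, > 100 mg/kg. Compound 4 also gives only a limit, > 10 mg/kg. No step can be read between compound 3 and compound 4, so the compounds shown leave open whether methyl in place of hydrogen changes the dose at all.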